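A few compounds are considered here, and "the series" means these few. Any claim that something is new, unique, unknown or untested is made for them only; others in the source may bear on it.

Working notes on the series.

Compound 2 `CC(C)(C)c1ccc(C(=O)N2CCC3(CC2)C(=O)N(CC(=O)NCCCCNS(C)(=O)=O)CN3c2ccccc2)cc1` is the reference point for the step considered here. In an assay on HEK293 cells for displacement of a labelled ligand from NPC1-like intracellular cholesterol transporter 1 (Homo sapiens) (a higher number here means a weaker inhibitor, a lower number a stronger inhibitor), compound 2 gives 4500 nM. Going by the values given here, the only other measured compound, compound 1 `CCOC(=O)C1CCN(C(=O)CN2CN(c3ccccc3)C3(CCN(C(=O)c4ccc(C(C)(C)C)cc4)CC3)C2=O)CC1`, gives 3100 nM in this assay, and the step of a 1.5-fold higher number from compound 1 to compound 2 (0.16 log units; within the scatter) shows that the two numbers are not separated beyond the scatter; compound 2 thus stands alongside compound 1, with no measured compound clearly stronger or weaker than it.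

Compound 3 `CC(C)(C)c1ccc(C(=O)N2CCC3(CC2)C(=O)N(CC(=O)NCCCCCO)CN3c2ccccc2)cc1` is the unmeasured compound. It differs from compound 2 by hydroxymethyl in place of methanesulfonamido on a saturated chain carbon, four bonds along the chain from an amide-type nitrogen. Among the compounds with values here, the one measured step that bears on it is the exchange at the same carbonyl carbon of the side chain, from compound 1 to compound 2, which came out as a 1.5-fold higher number from compound 1 to compound 2 (0.16 log units; within the scatter). That step replaced a whole ring-bearing substituent with an open chain and still stayed within the scatter, so a smaller exchange at the end of that chain is expected to give no step beyond the scatter in this assay, and the estimated step is no change at the digits printed from compound 2 to compound 3 (within the scatter). Compound 3 is therefore estimated at 4500 nM in this assay, with a range from 1500 nM to 13000 nM.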

Compound 3, half-maximal inhibitory concentration: 9400 nM
For compound 3 the middle estimate is 2.1-fold (0.32 log units) below the measured one; low and high end bracket the measured number.
By their numbers in this assay, from the lowest: compounds 1 and 2 (each within the scatter of the next); then compound 3.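

At the end of the side chain, the group is not interchangeable in this assay: hydroxymethyl in place of methanesulfonamido, on a saturated chain carbon four bonds along the chain from an amide-type nitrogen, gives a 2.1-fold higher number from compound 2 to compound 3 (0.32 log units; beyond the scatter) and, though modest, this step lies beyond the scatter. At the carbonyl carbon, (5-hydroxypentyl)amino in place of 4-(ethoxycarbonyl)piperidin-1-yl gives a 3.0-fold higher number from compound 1 to compound 3 (0.48 log units; beyond the scatter) and is also beyond the scatter, whereas the open chain of compound 2 stayed within the scatter of compound 1, so an open chain at this carbonyl carbon does not by itself fix the number and its end group also counts. No measurement here speaks to the reason for the weaker number of compound 3.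

One pair cannot separate the loss of methanesulfonamido from the arrival of hydroxymethyl, and a primary amine, a carboxylic acid or a methyl ether at the end of the same chain would help to tell these apart. Also open, on these data alone, is how a longer or shorter chain carrying methanesulfonamido would compare with compound 2, and whether any end group here can give a number clearly lower than that of compound 1.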